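The source may hold more compounds than are shown below. What is called first, only, known or untested is meant among the compounds shown, and "the series" means these compounds.

In a toxicity assay on cells (Fibroblast, Homo sapiens) for cytotoxicity (a lower number here means a stronger inhibitor, a higher number a weaker inhibitor), three compounds sharing one core have been measured. Compound 1 `CC(/C=C/C1=CCCCC1(C)C)=C\C=C\C(C)=C\COC(=O)c1ccccc1O` gives 150000 nM, compound 2 `CC(/C=C/C1=CCCCC1(C)C)=C\C=C\C(C)=C\COC(=O)c1c(O)cccc1O` gives 14000 nM, and compound 3 `COc1ccc(O)c(C(=O)OC/C=C(C)/C=C/C=C(C)/C=C/C2=CCCCC2(C)C)c1` gives 570000 nM, the highest of the three numbers. Compound 4 `CC(=O)Oc1ccccc1C(=O)OC/C=C(C)/C=C/C=C(C)/C=C/C1=CCCCC1(C)C` remains unmeasured. It differs from compound 3 by 2-acetoxyphenyl in place of 2-hydroxy-5-methoxyphenyl on a carbonyl carbon, with 2-acetoxyphenyl in place of 2-hydroxy-5-methoxyphenyl on a carbonyl carbon. Among the measured compounds shown here, two measured steps bear on this change. Adding methoxy gave a 3.8-fold higher number from compound 1 to compound 3 (0.58 log units; beyond the scatter), a modest step, and compound 4 lacks that methoxy. Adding hydroxy gave an 11-fold lower number from compound 1 to compound 2 (1.03 log units; beyond the scatter), a large step, but compound 4 carries no such extra hydroxy. For the measured compounds named here, no measured step covers the acetoxy group itself. A modest drop is therefore expected, with an estimated 2.9-fold lower number from compound 3 to compound 4 (0.45 log units; beyond the scatter). Compound 4 is estimated at 200000 nM, within a range of 50000 nM to 700000 nM.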

Compound 4, half-maximal inhibitory concentration: 150000 nM
For compound 4 the middle estimate is 1.3-fold (0.12 log units) above the measured one; low and high end bracket the measured number.
By their numbers in this assay, from the lowest: compound 2; then compounds 1 and 4 (each within the scatter of the next); then compound 3.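

In this assay, acetyl in place of hydrogen on the oxygen on the aromatic ring leaves the number unmoved (no change at the digits printed from compound 1 to compound 4 (within the scatter)), so capping that hydroxy costs nothing measurable here. Compound 4 therefore sits where compound 1 does relative to the other two compounds (a 3.8-fold lower number from compound 3 to compound 4 (0.58 log units; beyond the scatter); an 11-fold higher number from compound 2 to compound 4 (1.03 log units; beyond the scatter)). No available measurement explains this result. Still open, as far as these compounds go, is whether a longer acyl chain such as butyryl, or a methyl ether on that oxygen, would also leave the number unchanged. Equally open, from the compounds shown here alone, is how an amine or a carboxylic acid on the ring would compare.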